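The compounds below may be only part of what the source reports. "The series", "measured", "known", "first", "only" and "open" are said of these compounds alone.

Compound 1 `COc1ccccc1N1CCN(CCC(Oc2ccc(NC(=O)c3ccccc3OCCCC(=O)O)cc2)c2ccccc2)CC1`: 79.4 nM
Compound 2 `COc1ccccc1N1CCN(CCC(Oc2ccc(C(=O)Nc3ccccc3OCCCC(=O)O)cc2)c2cccc(C)c2)CC1`: 251 nM

Both numbers come from an assay on Prostate gland (Oryctolagus cuniculus) for inhibition of Adrenergic receptor alpha-1 (Homo sapiens); on this read-out lower numbers stand for tighter binding and higher numbers for weaker binding. Compound 2 gives the higher of the two values, and its gap to compound 1 lies beyond the usual scatter. Compound 3 `COc1ccccc1N1CCN(CCC(Oc2ccc(C(=O)Nc3ccccc3OCCCC(=O)O)cc2)c2ccc(Br)cc2)CC1` differs from compound 2 in one place: 4-bromophenyl in place of 3-methylphenyl on a saturated chain carbon bound to an oxygen on an aromatic ring and a saturated chain carbon. Within the data shown here, no measured pair shows this kind of exchange, so there is nothing to suggest a step in either direction beyond the scatter. Compound 3 is therefore expected to give about 220 nM, with a likely range from 90 nM to 550 nM. This estimate means a step of a 1.1-fold lower number from compound 2 to compound 3 (0.06 log units; within the scatter) that is expected to stay within the scatter.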

Compound 3, dissociation constant: 100 nM
Estimate against measurement, compound 3: 2.2-fold (0.34 log units) above; low and high end bracket the measured number.
By their numbers in this assay, from the lowest: compounds 1 and 3 (each within the scatter of the next); then compound 2.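

In this assay the group on a saturated chain carbon bound to an oxygen on an aromatic ring and a saturated chain carbon proves able to shift the number: 4-bromophenyl in place of 3-methylphenyl gives a 2.5-fold lower number from compound 2 to compound 3 (0.40 log units; beyond the scatter) even though both groups have the same heavy-atom count and one aromatic ring. Nothing available explains this step. The compounds shown cannot separate the effect of the bromine from that of its place on the ring. On these data alone, how a chlorine or a methoxy group there would read remains open.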